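Swapping a cyclic amidine for an imidazolylsulfanyl group

A few compounds are considered here, and "the series" means these few. Any claim that something is new, unique, unknown or untested is made for them only; others in the source may bear on it.

Measured so far in an assay on isolated protein for binding affinity to Alpha-1A adrenergic receptor (Rattus norvegicus), read by radioligand binding; on this read-out lower numbers stand for stronger inhibition and higher numbers for weaker inhibition:
- compound 1 `CCS(=O)(=O)Nc1cccc2c1CCCC2c1c[nH]cn1`: 46.8 nM
- compound 2 `CCS(=O)(=O)Nc1cccc(C2CCNC2)c1`: 501 nM
- compound 3 `CCS(=O)(=O)Nc1cccc(NC2=NCCN2)c1`: 2950 nM

Compound 3 gives the highest number of the three, with compound 2 nearest and compound 1 furthest away. Compound 4 `CCS(=O)(=O)Nc1cccc(Sc2c[nH]cn2)c1` is not yet measured; it differs from compound 3 in one place: a group of 6 heavy atoms (3 carbon, 2 nitrogen, 1 sulfur; one five-membered aromatic ring with 2 hetero atoms) in place of a group of 6 heavy atoms (3 carbon, 3 nitrogen; one five-membered non-aromatic ring with 2 hetero atoms), on an aromatic carbon.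

Within the data shown here, only one measured step bears on this change. Going a 5.9-fold higher number from compound 2 to compound 3 (0.77 log units; beyond the scatter), the number rose when the five-membered non-aromatic ring with 1 hetero atom gave way to the five-membered non-aromatic ring with 2 hetero atoms. Among the measured compounds shown here, compound 4 now removes that ring again, but what enters has no measured counterpart here; compound 1 differs from compound 4 in more than one place, so its value shows only that a different arrangement reaches a far lower number. Taking the reversal of the earlier rise as a rough guide, a modest drop is expected, as a 7.4-fold lower number from compound 3 to compound 4 (0.87 log units; beyond the scatter). Compound 4 is therefore estimated at 400 nM, with a range from 60 nM to 2500 nM.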

Compound 4, inhibition constant: < 10000 nM
Compound 4: only a limit was reported; the forecaster's own chance of this, stated with the estimate: 5%; the middle value lies beyond the limit too.
By their numbers in this assay, from the lowest: compound 1; then compound 2; then compound 3.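

In this assay compound 4 gives < 10000 nM, which is a limit and not a number. The steps to compound 4 from compound 2 and compound 3 therefore cannot be read: the limit of < 10000 nM in this assay, at which 1 of the 4 values shown sits.

The compounds shown leave open where compound 4 stands relative to compound 2 and compound 3.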